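The compounds below may be only part of what the source reports. "The series", "measured", "known", "first", "only" and "open" are said of these compounds alone.

Compound 1 `O=C(O)CCNC(=O)c1cc(C(=O)Nc2ccc3c(c2)CNCC3)cc([N+](=O)[O-])c1` | 2300 nM
Compound 2 `O=C(O)CC(NC(=O)c1cc(C(=O)Nc2ccc3c(c2)CNCC3)cc([N+](=O)[O-])c1)c1ccccc1` | 710 nM

Among the measured compounds shown here, in a functional assay on a cell-free system (plasma, Homo sapiens) for inhibition, with Plasma (Rattus norvegicus) as the target (on this read-out lower numbers stand for stronger inhibition and higher numbers for weaker inhibition), compound 2 gives 710 nM, the lower of the two numbers measured so far. Compound 3 `COc1ccc(C(CC(=O)O)NC(=O)c2cc(C(=O)Nc3ccc4c(c3)CNCC4)cc([N+](=O)[O-])c2)cc1` has methoxy in place of hydrogen on an aromatic carbon. For the measured compounds named here, the only measured step that bears on this is a 3.2-fold lower number from compound 1 to compound 2 (0.51 log units; beyond the scatter), a modest one that introduced the phenyl itself. Going by the values given here, no measurement yet tests a substituent on that phenyl, so a small step of uncertain direction is expected, possibly none beyond the scatter. The expected step is a 1.1-fold lower number from compound 2 to compound 3 (0.04 log units; within the scatter). The estimated value for compound 3 is 650 nM, with an expected range from 250 nM to 1700 nM.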

Compound 3, half-maximal inhibitory concentration: 450 nM
For compound 3 the middle estimate is 1.4-fold (0.16 log units) above the measured one; the measured number falls inside the stated range.
By their numbers in this assay, from the lowest: compounds 3 and 2 (each within the scatter of the next); then compound 1.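

In this assay, methoxy para to a large group on the phenyl ring gives a 1.6-fold lower number from compound 2 to compound 3 (0.20 log units; within the scatter), so this ring position accepts the group with no change beyond the scatter. The 4-methoxyphenyl in place of hydrogen on the chain carbon gives a 5.1-fold lower number from compound 1 to compound 3 (0.71 log units; beyond the scatter), which shows that an aryl group at that carbon still stands apart from hydrogen once the ring carries a substituent. Nothing available gives a reason for either step. Still open, from the compounds shown here alone, is whether an amine or a chlorine atom at this ring position would shift the number beyond the scatter, and whether methoxy would behave the same way elsewhere on the ring.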